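Notes on the ring-nitrogen substituent step to compound 4

The source may hold more compounds than are shown below. What is called first, only, known or untested is meant among the compounds shown, and "the series" means these compounds.

In a functional assay on MCF7 cells (Homo sapiens) for antiproliferative activity, read by sulforhodamine B assay, with a stated time of 72 h (on this read-out lower numbers stand for stronger inhibition and higher numbers for weaker inhibition), compound 1 `COc1cccc(COc2ccc(-c3cc(CN4CCN(Cc5ccc(C(F)(F)F)cc5)CC4)no3)cc2)c1` gives 2000 nM, compound 2 `COc1cc(COc2ccc(-c3cc(CN4CCN(Cc5ccc(C(F)(F)F)cc5)CC4)no3)cc2)cc(OC)c1` gives 100 nM, and compound 3 `N#Cc1cccc(COc2ccc(-c3cc(CN4CCN(c5ccc(F)cc5)CC4)no3)cc2)c1` gives 2400 nM. Among the compounds with values here, the only single-point step measured, a 20-fold lower number from compound 1 to compound 2 (1.30 log units; beyond the scatter), concerns a methoxy group on an aromatic carbon. Compound 3 stands at the highest number of the three, within the scatter of compound 1 and well apart from compound 2. Compound 4 `N#Cc1cccc(COc2ccc(-c3cc(CN4CCN(CC5CC5)CC4)no3)cc2)c1` differs from compound 3 by cyclopropylmethyl in place of 4-fluorophenyl on an amine nitrogen in a ring. Within the data shown here, no measured step touches the group on this ring nitrogen; compound 1 and compound 3 differ in two places, so their two values alone settle nothing about it. The step is therefore expected to be a 1.3-fold higher number from compound 3 to compound 4 (0.10 log units; within the scatter). Compound 4 is estimated at 3000 nM in this assay, with a range of 800 nM to 12000 nM.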

Compound 4, half-maximal inhibitory concentration: 3500 nM
Compound 4: middle estimate off by 1.2-fold (0.07 log units), on the low side; the range from low to high includes it.
By their numbers in this assay, from the lowest: compound 2; then compounds 1, 3 and 4 (each within the scatter of the next).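

Within the data shown here, the step on the ring nitrogen, a 1.5-fold higher number from compound 3 to compound 4 (0.16 log units; within the scatter) in this assay, is the first measured at this position. Cyclopropylmethyl replaces 4-fluorophenyl, so a three-membered non-aromatic ring stands in for a six-membered aromatic one, and the number stays within the scatter; in this pair, an aromatic ring on this nitrogen is not needed to keep the read-out at this level. Nothing measured speaks to why the two groups read alike. Open, from the compounds shown here alone, is whether an acetyl group or a longer alkyl chain on this nitrogen would shift the number. Also open, going by these compounds, is whether this exchange stays within the scatter alongside the methoxy groups of compound 2.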